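The source may report more compounds than this note shows. Statements on the series, on what has been measured and on what is new or still open speak of the compounds shown alone.

Measured in a functional assay (brain) for inhibition, with Rattus norvegicus as the target; a lower number here means a stronger inhibitor, a higher number a weaker inhibitor:
- compound 1 `COc1cc2c(cc1O)CCC(C(=O)NCc1ccccc1)O2`: 16600 nM
- compound 2 `COc1cc2c(cc1O)C(=O)CC(C(=O)O)O2`: > 300000 nM (a limit of the assay)

Compound 2 has no number in this assay, and its > 300000 nM is only a limit. Compound 3 `COc1cc2c(cc1O)C(=O)CC(C(N)=O)O2` is still unmeasured and carries one change from compound 2, amino in place of hydroxy on a carbonyl carbon, or carboxy to carbamoyl.

Within the data shown here, no measured pair isolates this change. Among the measured compounds shown here, compound 1, at 16600 nM, shows only that a number can be reached in this assay, and it differs from compound 2 in more than one place. The expected step of an at least 1.5-fold lower number from compound 2 to compound 3 (0.17 log units; that floor lies within the scatter) is therefore modest, towards stronger inhibition, and compound 3 may well stay at the limit. For compound 3 the estimate is 200000 nM, with an expected range of 60000 nM to 500000 nM.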

Compound 3, half-maximal inhibitory concentration: > 300000 nM
Compound 3: no number, only a limit; the forecaster's own chance of this, stated with the estimate: 45%; middle value at least 1.5-fold (0.17 log units) from the limit.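

Compound 2 and compound 3 give no numbers, only limits of the assay, so no step between them can be read: the limit of > 300000 nM in this assay, at which 2 of the 3 values shown sit.

The compounds shown leave open whether amino in place of hydroxy on a carbonyl carbon changes inhibition in either direction.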